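A few compounds are considered here, and "the series" means these few. Any claim that something is new, unique, unknown or untested is made for them only; others in the source may bear on it.

For the measured compounds named here, in a functional assay, read by fluorescence and spectrophotometry, with a stated time of 1 h (on this read-out higher numbers stand for an effect only at larger amounts of compound and lower numbers for an effect already at smaller amounts), compound 1 (`CCCCCCCCCCCCS(=O)(=O)/C=C/c1ccc(O)c(O)c1`) gives 8500 nM and compound 2 (`O=S(=O)(/C=C/c1ccc(O)c(O)c1)CC1CC1`) gives 10500 nM as its reading, so compound 2 stands within the scatter of the only other number. Compound 3 (`CCCCCS(=O)(=O)/C=C/c1ccc(O)c(O)c1`) has no number yet. Its change from compound 2 (butyl in place of cyclopropyl on a saturated chain carbon bound to a sulfonyl sulfur) is butyl in place of cyclopropyl on a saturated chain carbon bound to a sulfonyl sulfur. Going by the values given here, no measured pair differs in one place only, so no direct step is available as a guide. Compound 1 at 8500 nM and compound 2 at 10500 nM carry different groups on the sulfonyl sulfur and still sit within the scatter of each other. In this assay no step beyond the scatter is therefore expected, in either direction. The estimated move is a 1.1-fold lower number from compound 2 to compound 3 (0.04 log units; within the scatter) and stays within the scatter. For compound 3 the expected value is 9500 nM with an estimated range from 5000 nM to 18000 nM on this read-out.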

Compound 3, half-maximal effective concentration: 8100 nM
Estimate against measurement, compound 3: 1.2-fold (0.07 log units) above; low and high end bracket the measured number.
By their numbers in this assay, from the lowest: compounds 3, 1 and 2 (each within the scatter of the next).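

In this assay, for the compounds shown here, the first direct step at this place, on a saturated chain carbon bound to a sulfonyl sulfur, is a 1.3-fold lower number from compound 2 to compound 3 (0.11 log units; within the scatter) and shows that butyl in place of cyclopropyl, with the three-membered ring gone, gives a reading within the scatter. The step further out along the chain, hydrogen in place of heptyl, is a 1.0-fold lower number from compound 1 to compound 3 (0.02 log units; within the scatter) and also stays within the scatter, so none of the three groups at this place separates from the others in this assay. Nothing available bears on the reason for these readings.

How an amine or a carboxylic acid on this chain would read remains open, as the groups shown there are all carbon only. Also open, on these data alone, is any change to the shared core, such as a methoxy group in place of a hydroxyl group.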